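A few compounds are considered here, and "the series" means these few. Any claim that something is new, unique, unknown or untested is made for them only; others in the source may bear on it.

Within the data shown here, compound 1, `CC(C)(Oc1ccccc1F)C1OCC(C/C=C\CCC(=O)O)C(c2cccnc2)O1`, is one of two compounds measured in a functional assay for inhibition, with Homo sapiens as the target; a higher number here means weaker binding, a lower number tighter binding. In this assay compound 1 gives 166 nM. Compound 2, `COc1ccc(SC(C)(C)C2OCC(C/C=C\CCC(=O)O)C(c3cccnc3)O2)c([N+](=O)[O-])c1`, gives 158 nM in this assay, and the two numbers lie within the usual scatter of each other, so neither can be placed ahead of the other. The two measured compounds differ in more than one place, so they tell nothing about any single change. Compound 3, `CC(C)(Cc1ccc(F)cc1)C1OCC(C/C=C\CCC(=O)O)C(c2cccnc2)O1`, has not yet been measured in this assay. Compared with compound 1 it carries 4-fluorobenzyl in place of 2-fluorophenoxy on a saturated chain carbon bound to two saturated chain carbons and a saturated ring carbon. Among the measured compounds shown here, no single-change step between measured compounds exists to calibrate this change, so the expectation rests on compound 1 alone, anchored at 166 nM. The expected step is a 1.2-fold higher number from compound 1 to compound 3 (0.08 log units; within the scatter), small and not beyond the scatter, with no direction clearly favored. Compound 3 is estimated at 200 nM, expected to fall between 60 nM and 700 nM.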

Compound 3, dissociation constant: 89.1 nM
For compound 3 the middle estimate is 2.2-fold (0.35 log units) above the measured one; measured number inside the range.
By their numbers in this assay, from the lowest: compounds 3, 2 and 1 (each within the scatter of the next).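

In this assay, among these compounds, the change to 4-fluorobenzyl in place of 2-fluorophenoxy on a saturated chain carbon bound to two saturated chain carbons and a saturated ring carbon gives the first single-change reading at this position: a 1.9-fold lower number from compound 1 to compound 3 (0.27 log units; within the scatter). This position therefore accepts a group with 0 hydrogen-bond acceptors in place of one with 1 hydrogen-bond acceptor, with no shift that can be told from the scatter. No measurement offered here bears on the reason for this result.

The compounds shown leave open whether an unsubstituted benzyl group, a primary amine or a morpholine at this position would move the number beyond the scatter. They also leave open whether the same change would give a similar step with a group other than the carboxylic acid chain on the shared core.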